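The source may hold more compounds than are shown below. What is called first, only, known or untested is meant among the compounds shown, and "the series" means these compounds.

Measured so far in a functional assay on MCF7 cells (Homo sapiens) for antiproliferative activity, read by MTT assay, with a stated time of 72 h; a higher number here means a weaker inhibitor, a lower number a stronger inhibitor:
compound 1 `COc1cc(-n2cnc3ccc(-c4ccc(Cl)cc4)cc32)cc(OC)c1OC`: 1320 nM
compound 2 `COc1ccccc1-c1ccc2ncn(-c3cc(OC)c(OC)c(OC)c3)c2c1`: 1750 nM

Among the measured compounds shown here, compound 2 carries the higher of these two numbers, but the only step that separates it from compound 1 is a 1.3-fold higher number from compound 1 to compound 2 (0.12 log units; within the scatter), so the two compounds cannot be ranked. Compound 3 `COc1cc(-n2cnc3ccc(-c4cccc([N+](=O)[O-])c4)cc32)cc(OC)c1OC` takes the next step: 3-nitrophenyl in place of 2-methoxyphenyl on an aromatic carbon. For the measured compounds named here, the one step measured so far also swaps the aromatic substituent in the same position, and it is a 1.3-fold higher number from compound 1 to compound 2 (0.12 log units; within the scatter). With only that to go on, no change beyond the scatter is expected in this assay, and the expected step from compound 2 is a 1.2-fold lower number from compound 2 to compound 3 (0.07 log units; within the scatter). Compound 3 is therefore estimated at 1500 nM, within a range from 600 nM to 4000 nM.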

Compound 3, half-maximal inhibitory concentration: 4560 nM
Estimate against measurement, compound 3: 3.0-fold (0.48 log units) below; measured number above the stated range.
By their numbers in this assay, from the lowest: compounds 1 and 2 (each within the scatter of the next); then compound 3.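

In this assay this position on the shared core does respond to what it carries: 3-nitrophenyl gives a 2.6-fold higher number from compound 2 to compound 3 (0.42 log units; beyond the scatter) and a 3.5-fold higher number from compound 1 to compound 3 (0.54 log units; beyond the scatter), whereas the earlier swap stayed within the scatter. With both of its steps beyond the scatter, compound 3 is the weakest of the three. Nothing measured here explains why 3-nitrophenyl stands apart. The three phenyl groups differ in both their substituent and where it sits, so those two changes cannot be separated. On these data alone, how an amine or a carboxylic acid would fare here remains open.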